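Ester to alcohol on the side chain of compound 1

A few compounds are considered here, and "the series" means these few. Any claim that something is new, unique, unknown or untested is made for them only; others in the source may bear on it.

In an assay on isolated protein for inhibition of protein deacetylase HDAC6 (Homo sapiens), read by fluorescence, tested at 1 uM (a higher number here means more inhibition at the concentration tested (going by the name of the read-out), a lower number less inhibition), compound 1 `COC(=O)CCCC[C@H](NC(=O)OC(C)(C)C)C(=O)NC1CCCC1` gives 40%. Compound 2 `O=C(O)CCCCC[C@H](NC(=O)OCc1ccccc1)C(=O)NC1CCCC1` in this assay gives 40%, and the two values are level within the scatter, so compound 1 stands with compound 2 on the numbers available. Compound 3 `CC(C)(C)OC(=O)N[C@@H](CCCCCCO)C(=O)NC1CCCC1` has no value yet in this assay. It differs from compound 1 in one place: 2-hydroxyethyl in place of methoxycarbonyl on a saturated chain carbon, five bonds along the chain from an amide-type nitrogen and a carbonyl carbon. Among the measured compounds shown here, no measured pair covers a change of this kind. A small downward step is expected, a number 10 percentage points lower from compound 1 to compound 3 (within the scatter), though one inside the scatter would not surprise. For compound 3 the estimate in this assay is 30%, within 10% to 55%.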

Compound 3, a percentage reported as inhibition, at one concentration (the size of the read-out at that concentration, not a potency): 3%
The estimate for compound 3 lay 27 percentage points above the measured number; measured number outside the range, below it.
By their numbers in this assay, from the lowest: compound 3; then compounds 1 and 2 (each within the scatter of the next).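

In this assay, the end of this side chain is sensitive to the group it carries: 2-hydroxyethyl in place of methoxycarbonyl gives a number 37 percentage points lower from compound 1 to compound 3 (beyond the scatter). The earlier compounds shown here, level with each other, gave no sign that a change at this place could matter so much. No measurement at hand accounts for the drop. Going by these compounds, whether an amine or a hydroxamic acid at the same chain end would hold or raise the number remains open. So does whether the drop follows from the hydroxyl entering or from the ester carbonyl leaving.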